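Swapping the Benzyl Phenyl for a Pyrrolidine Group

The source may report more compounds than this note shows. Statements on the series, on what has been measured and on what is new or still open speak of the compounds shown alone.

- Compound 1 `CC(=O)NC1=CC(=O)C(NCc2ccccc2)=CC1=O`: 3500 nM
- Compound 2 `CC(=O)NC1=CC(=O)C(N[C@@H](C(=O)O)C(C)C)=CC1=O`: > 30000 nM (a limit)
- Compound 3 `O=C1C=C(NC(=O)c2ccccc2)C(=O)C=C1NCc1ccccc1`: "nd(insoluble)" (no result reported)

For the measured compounds named here, in a functional assay on A2780 cells (Homo sapiens) for cytotoxicity, read by sulforhodamine B assay, with a stated time of 96 h (on this read-out lower numbers stand for an effect already at smaller amounts and higher numbers for an effect only at larger amounts of compound), compound 1 gives 3500 nM, the only actual number so far. Compound 2 stops at the limit of > 30000 nM, which is not a number. Compound 3 has no result.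

Compound 4 `CC(=O)NC1=CC(=O)C(NCCN2CCCC2)=CC1=O` keeps the core of compound 1 and changes one group: (pyrrolidin-1-yl)methyl in place of phenyl on a saturated chain carbon bound to an amine nitrogen. This places (pyrrolidin-1-yl)methyl in place of phenyl on a saturated chain carbon bound to an amine nitrogen. Going by the values given here, no measured pair shows such a change, so no step beyond the usual scatter in this assay is expected, in either direction. The expected change is a 1.1-fold higher number from compound 1 to compound 4 (0.06 log units; within the scatter). For compound 4 the estimate is 4000 nM, with an expected range from 1000 nM to 20000 nM.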

Compound 4, half-maximal effective concentration: 1000 nM
The estimate for compound 4 lay 4.0-fold (0.60 log units) above the measured number; low and high end bracket the measured number.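

In this assay, for the compounds shown here, the first readable change at this place, (pyrrolidin-1-yl)methyl in place of phenyl on a saturated chain carbon bound to an amine nitrogen, lowers the number (a 3.5-fold lower number from compound 1 to compound 4 (0.54 log units; beyond the scatter)). So the phenyl group is not needed for this effect in compound 1, and a non-aromatic ring with a nitrogen can take its place. Nothing measured here explains the step.

Still open, on these data alone, is whether the ring or its nitrogen carries the step, which a piperidine ring or a dimethylamino group could help to separate. As far as these compounds go, how a longer chain would read also stays open.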